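Amide swap in a methoxy-bearing dienamide series

This account rests on a few compounds, and the source may have more. Where it says the series, first, only, none or still open, it means among the compounds named here.

Compound 1 `CC(/C=C/CC(C)CCCC(C)C)=C\C(=O)NC(C)C` and compound 2 `CC(/C=C/CC(C)CCCC(C)C)=C\C(=O)N(C)C` share one core and differ by dimethylamino in place of isopropylamino on a carbonyl carbon. In a physicochemical assay for lipophilicity (on this read-out higher numbers stand for higher lipophilicity and lower numbers for lower lipophilicity), compound 1 gives 5.65 and compound 2 gives 4.94, so the step is a number 0.71 log units lower from compound 1 to compound 2 (beyond the scatter).

Compound 3 `COC(C)(C)CCCC(C)C/C=C/C(C)=C/C(=O)NC(C)C` carries a different core; the difference from compound 1 is methoxy in place of hydrogen on a saturated chain carbon bound to three saturated chain carbons, and in this assay compound 3 gives 4.45, a step of a number 1.20 log units lower from compound 1 to compound 3 (beyond the scatter).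

Compound 4 `COC(C)(C)CCCC(C)C/C=C/C(C)=C/C(=O)N(C)C`, not yet measured, differs from compound 3 by dimethylamino in place of isopropylamino on a carbonyl carbon; the place is the same word for word as for the first pair, so this is the same change. The expected step of a number 0.71 log units lower from compound 3 to compound 4 (beyond the scatter) rests on compound 1 and compound 2, where a number 0.71 log units lower from compound 1 to compound 2 (beyond the scatter) was seen. For compound 4 in this assay the estimate is 3.74, expected between 3.4 and 4.1.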

Compound 4, partition coefficient: 3.74
Compound 4: the middle estimate sits on the measured number at the digits printed; low and high end bracket the measured number.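

In this assay, dimethylamino in place of isopropylamino on the methoxy-bearing core gives a number 0.71 log units lower from compound 3 to compound 4 (beyond the scatter) and so matches a number 0.71 log units lower from compound 1 to compound 2 (beyond the scatter) at the digits printed, which means the change carries from one core to the other in this pair. The methoxy change, read on the dimethylamino side, gives a number 1.20 log units lower from compound 2 to compound 4 (beyond the scatter) and likewise matches a number 1.20 log units lower from compound 1 to compound 3 (beyond the scatter) in size, so the two changes add across these four compounds. This rests on a single pair of cores and does not show that the step holds on any other core, and no supporting data bear on why it repeats.

From the compounds shown here alone, whether the step holds for other amide groups, such as diethylamino or morpholino, remains open. Also open, going by these compounds, is how the amide swap behaves with a hydroxy or a carboxylic acid on the chain instead of methoxy.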